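The source may report more compounds than this note shows. Statements on the series, on what has been measured and on what is new or still open speak of the compounds shown alone.

Of the compounds shown here, three built on one shared core have been tested in a functional assay on HL-60 cells (Homo sapiens) for cytotoxicity, read by MTT assay, with a stated time of 24 h; on this read-out higher numbers stand for weaker inhibition and lower numbers for stronger inhibition. Compound 1 `COC(=O)/C(=C\c1ccc(OC(=O)c2ccccc2OC)cc1)Sc1ccnc2cc(Cl)ccc12` carries a 2-methoxyphenyl on the carbonyl carbon of its ester, and in this assay compound 1 gives 44500 nM. Compound 2 `COC(=O)/C(=C\c1ccc(OC(=O)c2cc(OC)cc(OC)c2)cc1)Sc1ccnc2cc(Cl)ccc12`, with a 3,5-dimethoxyphenyl in that place, gives 19000 nM. Compound 3 `COC(=O)/C(=C\c1ccc(OC(=O)c2cccc(OC)c2OC)cc1)Sc1ccnc2cc(Cl)ccc12`, with a 2,3-dimethoxyphenyl, gives 13000 nM. Among these three numbers compound 3 sits at the low end: its step from compound 1 is beyond the scatter a 3.4-fold lower number from compound 1 to compound 3 (0.53 log units; beyond the scatter), whereas its step from compound 2 is within it a 1.5-fold lower number from compound 2 to compound 3 (0.16 log units; within the scatter), so compounds 2 and 3 cannot be told apart on these data. The step from compound 1 to compound 2 is modest a 2.3-fold lower number from compound 1 to compound 2 (0.37 log units; beyond the scatter).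

Compound 4 `COC(=O)/C(=C\c1ccc(OC(=O)c2ccc(OC)c(OC)c2OC)cc1)Sc1ccnc2cc(Cl)ccc12` has not yet been measured. It differs from compound 3 by methoxy in place of hydrogen on an aromatic carbon. Going by the values given here, the closest precedent is the step from compound 1 to compound 3, which was likewise methoxy in place of hydrogen on an aromatic carbon and gave a 3.4-fold lower number from compound 1 to compound 3 (0.53 log units; beyond the scatter); against that, the step from compound 2 to compound 3 shows that rearranging methoxy groups can also stay within the scatter. A small lowering, or none beyond the scatter, is therefore expected. The expected step is a 1.4-fold lower number from compound 3 to compound 4 (0.16 log units; within the scatter). Compound 4 is estimated at 9000 nM, within a range from 4000 nM to 20000 nM.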

Compound 4, half-maximal inhibitory concentration: 2080 nM
The estimate for compound 4 lay 4.3-fold (0.64 log units) above the measured number, outside the stated range (below it).
By their numbers in this assay, from the lowest: compound 4; then compounds 3 and 2 (each within the scatter of the next); then compound 1.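

In this assay, going by these compounds alone, a single methoxy in place of hydrogen, on an aromatic carbon ortho to a methoxy group and para to a large group, gives a 6.3-fold lower number from compound 3 to compound 4 (0.80 log units; beyond the scatter), a step larger than any seen among the earlier compounds. The 2,3,4-trimethoxyphenyl group also stands clearly apart from the 3,5-dimethoxyphenyl group, with a 9.1-fold lower number from compound 2 to compound 4 (0.96 log units; beyond the scatter), and from the 2-methoxyphenyl group, with a 21-fold lower number from compound 1 to compound 4 (1.33 log units; beyond the scatter), so changes at this one place on the ester can shift the number widely while the shared core stays the same. Nothing available explains why this added methoxy has such an effect.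

Going by these compounds, with only methoxy groups on this ring, it remains open whether a hydroxy group, a fluorine atom, an amine or a longer chain such as ethoxy at the same carbon would give a similarly low number. On these data alone, it also remains open whether the three methoxy groups need this exact arrangement, as a 3,4,5-trimethoxyphenyl group would help to show.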